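The source may hold more compounds than are shown below. What is called first, only, known or untested is meant among the compounds shown, and "the series" means these compounds.

Measured so far:
- compound 1, `CCCOc1ccc(NC(=O)CCCCCCCSc2nnc(Cc3nn(C)c(=O)c4ccccc34)n2C)cc1`, in an assay on isolated protein (Mus musculus) for inhibition of IL15-IL15 receptor (Homo sapiens), read by resazurin assay, with stated times of 30 min and 2.5 days; a lower number here means a stronger inhibitor, a higher number a weaker inhibitor: 1600 nM
- compound 2, `Cn1c(Cc2nn(C)c(=O)c3ccccc23)nnc1SCC(=O)Nc1ccc(O)cc1`: "not active" (no number reported)
- compound 3, `Cn1c(Cc2nn(C)c(=O)c3ccccc23)nnc1SCCCCCCCCCC(=O)Nc1ccc(Cl)cc1Cl`: 2300 nM

All three share one core. Compound 1 gives the lowest of the two numbers reported, but compound 3 sits so close that the two cannot be told apart, and compound 2 returned no number at all. The unmeasured compound 4, `Cc1ccc(NC(=O)CCCCCCCSc2nnc(Cc3nn(C)c(=O)c4ccccc34)n2C)c(Cl)c1`, keeps the chain of compound 1 and changes only the group on the amide-type nitrogen: 2-chloro-4-methylphenyl in place of 4-propoxyphenyl on an amide-type nitrogen. Among the compounds with values here, no pair of measured compounds isolates such a swap, so in this assay only a small step is expected, in either direction, likely not beyond the scatter. Compound 4 is estimated at 2000 nM, within 800 nM to 5000 nM. That estimate corresponds to an expected step of a 1.3-fold higher number from compound 1 to compound 4 (0.10 log units; within the scatter).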

Compound 4, half-maximal inhibitory concentration: 2300 nM
Estimate against measurement, compound 4: 1.2-fold (0.06 log units) below, within the range that was stated.
By their numbers in this assay, from the lowest: compounds 1, 3 and 4 (each within the scatter of the next).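

In this assay, putting 2-chloro-4-methylphenyl in place of 4-propoxyphenyl on an amide-type nitrogen gives a 1.4-fold higher number from compound 1 to compound 4 (0.16 log units; within the scatter), so this step cannot be told apart from repeat-measurement noise. The entering group carries a chlorine and no hydrogen-bond acceptor, yet the number stays within the scatter. No supporting data bear on why this is so. Still open, on these data alone, is whether a carboxylic acid or an amine on this aryl group would move the number, and what a shorter or longer chain would do with 2-chloro-4-methylphenyl in place.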